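Demethylation of the dimethoxyphenyl arm in a pyrazole sulfonamide pair

This account rests on a few compounds, and the source may have more. Where it says the series, first, only, none or still open, it means among the compounds named here.

Compound 1 `COc1ccc(OC)c(-c2cc(-c3ccccc3)nn2-c2ccc(S(N)(=O)=O)cc2)c1` gives 13600 nM in a functional assay on cells (Cancer cell lines, Homo sapiens) for cytotoxicity, read by sulforhodamine B assay, with a stated time of 48 h (on this read-out higher numbers stand for weaker inhibition of growth and lower numbers for stronger inhibition of growth), the highest of the two numbers seen, with compound 2 `COc1ccc(OC)c(-c2cc(-c3ccccc3)nn2-c2ccc(S(=O)(=O)NC(C)=O)cc2)c1` at 13300 nM nearest, a gap within the scatter. Going by the values given here, the single measured step, a 1.0-fold lower number from compound 1 to compound 2 (0.01 log units; within the scatter), touches only the sulfonamide nitrogen and says nothing about the aryl arm. Compound 3 `NS(=O)(=O)c1ccc(-n2nc(-c3ccccc3)cc2-c2cc(O)ccc2O)cc1` differs from compound 1 by 2,5-dihydroxyphenyl in place of 2,5-dimethoxyphenyl on an aromatic carbon. Among the compounds with values here, no measured step bears on this change, so no shift beyond the scatter is expected in this assay. Compound 3 is therefore estimated at 12000 nM, range 4000 nM to 40000 nM, a step of a 1.1-fold lower number from compound 1 to compound 3 (0.05 log units; within the scatter) expected.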

Compound 3, concentration for 50% growth inhibition: 81300 nM
Beside the measured number, compound 3's estimate is 6.8-fold (0.83 log units) below it, and the stated range ends below it.
By their numbers in this assay, from the lowest: compounds 2 and 1 (each within the scatter of the next); then compound 3.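

On the aromatic carbon next to the ring nitrogen, the aryl arm is not a silent position in this assay: 2,5-dihydroxyphenyl in place of 2,5-dimethoxyphenyl gives a 6.0-fold higher number from compound 1 to compound 3 (0.78 log units; beyond the scatter), a modest weakening of growth inhibition. Only the sulfonamide nitrogen had been probed earlier, and that step stayed within the scatter. Nothing available accounts for the shift.

From the compounds shown here alone, whether the shift carries over to the acetylated sulfonamide of compound 2 remains open. So does how a 2,5-diaminophenyl arm, or a carboxylic acid on this arm, would read.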